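The compounds below may be only part of what the source reports. "The series", "measured", "known", "first", "only" and "open" are said of these compounds alone.

Compound 1 `COc1cc(-c2nn(-c3cccc(NC(=O)Nc4ccc(Cl)c(Cl)c4)c3)cc2-c2ccncc2)ccc1Cl` and compound 2 `O=C(Nc1cccc(-n2cc(-c3ccncc3)c(-c3ccc(Cl)c(O)c3)n2)c1)Nc1ccc(Cl)c(Cl)c1` share one core and differ at a single point, a hydrogen in place of a methyl on an oxygen on an aromatic ring. In a functional assay on NCI-H522 cells (Homo sapiens) for inhibition, read by sulforhodamine B assay, with a stated time of 48 h (on this read-out higher numbers stand for weaker inhibition of growth and lower numbers for stronger inhibition of growth), compound 1 gives 811 nM, and compound 2 gives 1190 nM. The step of a 1.5-fold higher number from compound 1 to compound 2 (0.17 log units; within the scatter) is the only one measured so far. Compound 2 thus holds the higher of the two numbers, but since its gap to compound 1 lies within the scatter, neither compound can be called the weaker.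

Compound 3 `O=C(Nc1cccc(-n2cc(-c3ccncc3)c(-c3ccc(Cl)c(O)c3)n2)c1)Nc1ccc(Cl)c(C(F)(F)F)c1` keeps the oxygen-bound hydrogen of compound 2 and changes the far end of the molecule instead: trifluoromethyl in place of chloro on an aromatic carbon. Going by the values given here, no measured step touches this part of the structure; the one known step concerns the oxygen on an aromatic ring and says nothing about the chloro that leaves or the trifluoromethyl that enters. Without such a guide, compound 3 is expected to stay close to compound 2, a step of a 1.3-fold lower number from compound 2 to compound 3 (0.12 log units; within the scatter) that is expected to remain within the scatter. Compound 3 is therefore estimated at 900 nM, with a range from 300 nM to 3000 nM.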

Compound 3, concentration for 50% growth inhibition: 720 nM
Estimate against measurement, compound 3: 1.3-fold (0.10 log units) above; the range from low to high includes it.
By their numbers in this assay, from the lowest: compounds 3, 1 and 2 (each within the scatter of the next).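

In this assay, going by these compounds alone, the change at the far end of the molecule gives a 1.7-fold lower number from compound 2 to compound 3 (0.22 log units; within the scatter), so this is the first reading of the aromatic carbon ortho to a chloro group and meta to a large group. At this position, trifluoromethyl, with 4 heavy atoms, takes the place of chloro, with 1 heavy atom, and the number stays within the scatter, so this larger group leaves no readable mark here, just as the change on the oxygen left none in the earlier step. Nothing measured on the chloro or the trifluoromethyl group bears on this result, so no account of it can be given from the data.

The compounds shown hold only these two groups at this position, so it remains open whether a nitrile, an amine, a carboxylic acid or a longer chain such as propyl on the same carbon would also stay within the scatter or move the number beyond it. On these data alone, it is equally open whether the same change would read alike with the methyl on the oxygen in place of the hydrogen that compound 2 and compound 3 carry.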